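The compounds below may be only part of what the source reports. "The series", "measured", "known", "first", "only" and "open" are said of these compounds alone.

In a functional assay on MGC-803 cells (Homo sapiens) for cytotoxicity, read by MTT assay, with a stated time of 48 h (a higher number here means a weaker inhibitor, a lower number a stronger inhibitor), compound 1 `CC1=NN(C(=O)COc2ccc(Cl)cc2)C(c2cc(Br)ccc2O)C1` gives 23600 nM and compound 2 `CC1=NN(C(=O)CCc2ccccc2)C(c2cc(Br)cc(Br)c2O)C1` gives 17100 nM. These two values lie within the scatter of each other, so the numbers do not separate compound 2 from compound 1. Compound 3 `CC1=NN(C(=O)COc2ccc(Cl)cc2)C(c2cc(Br)cc(Br)c2O)C1` has not yet been measured. It differs from compound 2 by 4-chlorophenoxy in place of benzyl on a saturated chain carbon bound to a carbonyl carbon. Among the measured compounds shown here, no measured pair shows this change alone. For the measured compounds named here, compound 1 also carries 4-chlorophenoxy, and its value of 23600 nM gives the only guide to what that group allows. In this assay the expected step is a 1.1-fold lower number from compound 2 to compound 3 (0.03 log units; within the scatter), which would be nothing beyond the scatter. For compound 3 the estimated value is 16000 nM, with an expected range of 7500 nM to 32000 nM.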

Compound 3, half-maximal inhibitory concentration: 50000 nM
Compound 3: middle estimate off by 3.1-fold (0.49 log units), on the low side, outside the stated range (above it).
By their numbers in this assay, from the lowest: compounds 2 and 1 (each within the scatter of the next); then compound 3.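

In this assay the exchange of benzyl for 4-chlorophenoxy on a saturated chain carbon bound to a carbonyl carbon now has a reading of its own: the step is a 2.9-fold higher number from compound 2 to compound 3 (0.47 log units; beyond the scatter) and it counts against 4-chlorophenoxy when the rest of compound 2 is kept. Bromo in place of hydrogen on an aromatic carbon, with 4-chlorophenoxy kept, moves the same way, as a 2.1-fold higher number from compound 1 to compound 3 (0.33 log units; beyond the scatter) shows, and neither effect could be read before, when no measured pair differed in one place. Nothing measured here bears on the reason for either step.

From the compounds shown here alone, whether the benzyl exchange gives the same step on the core of compound 1 remains open. So does how a dimethylamino group or a carboxylic acid would read on that saturated chain carbon.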